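This account rests on a few compounds, and the source may have more. Where it says the series, first, only, none or still open, it means among the compounds named here.

Among the compounds with values here, in an ADME assay on cells (Hepatocyte, Homo sapiens) for metabolic stability, with a stated time of 30 min (a lower number here means that less of the compound is left, a higher number that more of the compound is left), compound 2 `O=C(OC1CCC(CN2CCN(c3cc(=O)c4cc(C(F)(F)F)cc([N+](=O)[O-])c4s3)CC2)CC1)c1ccco1` gives 1%, the lower of the two numbers so far, while compound 1 `O=C(NC1CCC(CN2CCN(c3cc(=O)c4cc(C(F)(F)F)cc([N+](=O)[O-])c4s3)CC2)CC1)c1ccccc1` gives 92.9%. The next change leads to compound 3 `O=c1cc(N2CCN(CC3CCCCC3)CC2)sc2c([N+](=O)[O-])cc(C(F)(F)F)cc12`, with hydrogen in place of ((furan-2-yl)carbonyl)oxy on a saturated ring carbon. Within the data shown here, one measured step bears on this change, at the same ring carbon, where ((furan-2-yl)carbonyl)oxy stands in place of benzamido: a number 91.9 percentage points lower from compound 1 to compound 2 (beyond the scatter), large and beyond the scatter. Among the measured compounds shown here, compound 3 carries neither of those two groups, and no measured compound has hydrogen at that carbon, so this step is only a rough guide. A large rise in this assay is still expected, resting on that step, a number 91.9 percentage points lower from compound 1 to compound 2 (beyond the scatter). The expected step is a number 59 percentage points higher from compound 2 to compound 3 (beyond the scatter). Compound 3 is estimated at 60%, with an expected range from 25% to 92%.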

Compound 3, percent of the compound remaining: 82.4%
For compound 3 the middle estimate is 22.4 percentage points below the measured one; measured number inside the range.
By their numbers in this assay, from the lowest: compound 2; then compound 3; then compound 1.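

Notes on the saturated ring carbon: in this assay hydrogen in place of ((furan-2-yl)carbonyl)oxy gives a number 81.4 percentage points higher from compound 2 to compound 3 (beyond the scatter) and so separates the very low number of compound 2 from the part of the structure it shares with compound 3. Hydrogen in place of benzamido gives a number 10.5 percentage points lower from compound 1 to compound 3 (beyond the scatter) as a modest step, so a large group at this carbon does not by itself bring a low number, as compound 1 carries benzamido there and stands above compound 3. No measured evidence bears on why these groups differ.

Going by these compounds, compound 1 and compound 2 differ in both the amide or ester link and the benzene or furan ring, so the part of ((furan-2-yl)carbonyl)oxy that goes with the low number stays open. On these data alone, a benzoyloxy group or a furan-2-carboxamido group at this carbon would separate the two, and an amine or a carboxylic acid there remains unknown.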